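The source may report more compounds than this note shows. Statements on the series, on what has been measured and on what is new or still open speak of the compounds shown alone.

Measured compounds:
compound 1, `O=C(c1cc(Oc2cccc(NC(=S)Nc3ccc(Cl)c(C(F)(F)F)c3)c2)ccn1)N1CCCC1` — in a functional assay on MDA-MB-231 cells (Homo sapiens) for cytotoxicity, read by MTT assay, with a stated time of 48 h (on this read-out lower numbers stand for stronger inhibition and higher numbers for weaker inhibition), compound 1 gives 40200 nM.
compound 2, `CNC(=O)c1cc(Oc2cccc(NC(=S)Nc3ccc(OC(F)(F)F)cc3)c2)ccn1` — in this assay compound 2 gives a limit, > 100000 nM.

Compound 2 therefore stands at the limit of > 100000 nM in this assay, at which 1 of the 2 values shown sits, with no number of its own. Among the measured compounds shown here, compound 1 and compound 2 differ in more than one place, so their two values show only that compound 1 carries a number while compound 2 carries a limit. Compound 3, `O=C(c1cc(Oc2cccc(NC(=S)Nc3ccc(OC(F)(F)F)cc3)c2)ccn1)N1CCCC1`, is not yet measured; it differs from compound 2 by pyrrolidin-1-yl in place of methylamino on a carbonyl carbon. For the measured compounds named here, no measured pair shows this exchange alone. The nearest pointer is compound 1, which carries the (pyrrolidin-1-yl)carbonyl group with a different partner on the far side of the molecule and which gives 40200 nM. The step from compound 2 to compound 3 is expected to be an at least 1.6-fold lower number from compound 2 to compound 3 (0.22 log units; that floor lies within the scatter), toward a measurable number, with its size uncertain. Compound 3 is estimated at 60000 nM in this assay, in the range 20000 nM to 200000 nM.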

Compound 3, half-maximal inhibitory concentration: 37800 nM
Compound 3: the middle estimate sits 1.6-fold (0.20 log units) above what was measured; the range from low to high includes it.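

In this assay, pyrrolidin-1-yl in place of methylamino on a carbonyl carbon, with the 4-(trifluoromethoxy)phenyl group unchanged, gives an at least 2.6-fold lower number from compound 2 to compound 3 (0.42 log units; beyond the scatter), which is a reading of this exchange on its own. As far as these compounds go, its full size stays unknown because compound 2 carries a limit and not a number: the limit of > 100000 nM in this assay, at which 1 of the 3 values shown sits. With the (pyrrolidin-1-yl)carbonyl group in place, 4-(trifluoromethoxy)phenyl in place of 4-chloro-3-(trifluoromethyl)phenyl on an amide-type nitrogen gives a 1.1-fold lower number from compound 1 to compound 3 (0.03 log units; within the scatter), so the two groups cannot be told apart here.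

The compounds shown leave open whether another amine on the carbonyl carbon, such as piperidin-1-yl, morpholin-4-yl or dimethylamino, would give a lower number. They also leave open whether the exchange gives a similar step with 4-chloro-3-(trifluoromethyl)phenyl as the partner on the far side.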